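Changing the Aryl Group on the Amide-Type Nitrogen

This account rests on a few compounds, and the source may have more. Where it says the series, first, only, none or still open, it means among the compounds named here.

Compound 1, `O=C(Nc1cccc(F)c1)Nc1cc2ncncc2cc1OCc1cccc(Cl)c1`, gives 8300 nM in a functional assay on GBM3 cells (Homo sapiens) for antiproliferative activity, read by WST assay, with a stated time of 72 h; a lower number here means a stronger inhibitor, a higher number a weaker inhibitor.
Compound 2, `O=C(Nc1cccc(Cl)c1)Nc1cc2ncncc2cc1OCc1ccccc1`, gives 6400 nM.
Compound 3, `O=C(Nc1ccc(C(F)(F)F)cc1)Nc1cc2ncncc2cc1OCc1cccc(Cl)c1`, gives 5100 nM.

Compound 3 has the lowest of the three numbers, but neither neighbour is clear of it: compound 2 lies within the scatter, and so does compound 1, so no order can be read among the three measured compounds.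

Compound 4, `O=C(Nc1cccc(Cl)c1)Nc1cc2ncncc2cc1OCc1cccc(Cl)c1`, has not yet been measured. It differs from compound 3 by 3-chlorophenyl in place of 4-(trifluoromethyl)phenyl on an amide-type nitrogen. Among the compounds with values here, the one measured step that touches the same nitrogen is a 1.6-fold lower number from compound 1 to compound 3 (0.21 log units; within the scatter), a change within the scatter. Compound 2 already carries the 3-chlorophenyl group that enters here and differs from compound 4 only in another part of the shared core; the values of compound 2 and compound 3 lie within the scatter of each other. Within the data shown here, nothing among the measured compounds therefore points to a step beyond the scatter in this assay for this change.

Compound 4 is accordingly expected to show a 1.2-fold higher number from compound 3 to compound 4 (0.07 log units; within the scatter), that is, no movement beyond the scatter. The estimate for compound 4 is 6000 nM, expected to fall between 3000 nM and 12000 nM.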

Compound 4, half-maximal inhibitory concentration: 3500 nM
Compound 4: the middle estimate sits 1.7-fold (0.23 log units) above what was measured; measured number inside the range.
By their numbers in this assay, from the lowest: compounds 4, 3, 2 and 1 (each within the scatter of the next, the first and the last beyond it).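

In this assay, the exchange on the amide-type nitrogen, 3-chlorophenyl in place of 4-(trifluoromethyl)phenyl, gives a 1.5-fold lower number from compound 3 to compound 4 (0.16 log units; within the scatter), so two quite different aryl groups at this position remain indistinguishable, and chloro in place of hydrogen on an aromatic carbon likewise stays within the scatter, at a 1.8-fold lower number from compound 2 to compound 4 (0.26 log units; within the scatter). The new information comes from the exchange of one halogen for another on the aryl group of this nitrogen: chloro in place of fluoro on an aromatic carbon gives a 2.4-fold lower number from compound 1 to compound 4 (0.38 log units; beyond the scatter), the first step among these compounds to clear the scatter, though only modestly. No measurement offered here accounts for this step, so it stands as an observation only.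

The aryl groups shown on this nitrogen carry only fluoro, chloro or trifluoromethyl, so it remains open how the numbers would respond to an aryl group bearing an amine or a carboxylic acid, or to a longer alkyl chain in place of the aryl group. All the values also lie in one cell assay, which leaves open whether the modest step seen with chloro in place of fluoro would recur on other members of the series.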